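Swapping a pyridinylmethyl for a pyrimidinyl on the piperazine

The source may report more compounds than this note shows. Statements on the series, on what has been measured and on what is new or still open speak of the compounds shown alone.

Measured so far, in a functional assay on CCRF-CEM cells for antagonist activity at C-X-C chemokine receptor type 4 (Homo sapiens), read by calcium flux, with stated times of 25 min and 90 s; a higher number here means a weaker inhibitor, a lower number a stronger inhibitor:
compound 1 `CC(C)N1CCN(c2cccc3c2C[C@H](CN(C)[C@H]2CCCc4cccnc42)NC3)CC1` gives 16.9 nM;
compound 2 `CN(C[C@H]1Cc2c(cccc2N2CCN(Cc3ccccn3)CC2)CN1)[C@H]1CCCc2cccnc21` gives 4.47 nM;
compound 3 `CN(C[C@H]1Cc2c(cccc2N2CCN3CCC[C@@H]3C2)CN1)[C@H]1CCCc2cccnc21` gives 3.59 nM.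

Compound 2 stands second of the three; its gap to compound 3 is within the scatter, while the step from compound 1 to compound 2 is a 3.8-fold lower number from compound 1 to compound 2 (0.58 log units; beyond the scatter). Compound 4 `CN(C[C@H]1Cc2c(cccc2N2CCN(c3ncccn3)CC2)CN1)[C@H]1CCCc2cccnc21` differs from compound 2 by pyrimidin-2-yl in place of (pyridin-2-yl)methyl on an amine nitrogen in a ring. Within the data shown here, no measured step changes this amine substituent from one aromatic ring to another; the nearest is the step to compound 2, and the step from compound 1 to compound 3 concerns a different position. Compound 4 is therefore expected to stay close to compound 2, a 1.3-fold higher number from compound 2 to compound 4 (0.13 log units; within the scatter), within the scatter. The estimate for compound 4 is 6 nM, between 2 nM and 18 nM.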

Compound 4, half-maximal inhibitory concentration: 30.7 nM
For compound 4 the middle estimate is 5.1-fold (0.71 log units) below the measured one; measured number above the stated range.
By their numbers in this assay, from the lowest: compounds 3 and 2 (each within the scatter of the next); then compounds 1 and 4 (each within the scatter of the next).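

On this amine nitrogen in a ring, one aromatic group cannot simply stand in for another: in this assay, pyrimidin-2-yl in place of (pyridin-2-yl)methyl gives a 6.9-fold higher number from compound 2 to compound 4 (0.84 log units; beyond the scatter). Set against isopropyl, pyrimidin-2-yl gives a 1.8-fold higher number from compound 1 to compound 4 (0.26 log units; within the scatter), so the gain seen with (pyridin-2-yl)methyl does not carry over to it. Nothing measured here explains this difference. This change swaps the ring and removes the methyl link together, and the compounds shown cannot separate the two. A (pyrimidin-2-yl)methyl group or a pyridin-2-yl group on this nitrogen would bear on that question.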